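The source may report more compounds than this note shows. Statements on the series, on what has been measured and on what is new or still open speak of the compounds shown alone.

Measured compounds:
- Compound 1 `C=CCCC(=O)N[C@H]1[C@@H](OCCc2ccccc2)O[C@H](CO)[C@@H](O)[C@@H]1O`. In a functional assay on A-375 cells (Homo sapiens), read by thymidine incorporation (on this read-out higher numbers stand for weaker inhibition and lower numbers for stronger inhibition), compound 1 gives > 50 uM, which is a limit of the assay and not a number.
- Compound 2 `CCCCC(=O)N[C@H]1[C@@H](OCCc2ccccc2)O[C@H](COCC(CO)(CO)CO)[C@@H](O)[C@@H]1O`. In this assay compound 2 gives > 50 uM, a limit.
- Compound 3 `C=CCCC(=O)N[C@H]1[C@@H](OCCc2ccccc2)O[C@H](CO)[C@@H](O)[C@@H]1OS(=O)(=O)O`. In this assay compound 3 gives > 50 uM, a limit.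

Compound 1 stands only at a limit in this assay, as do the other two values shown, so no ordering among the three can be read. Among the compounds with values here, the one step between measured compounds that differ in a single place, a step that the two limits leave unreadable from compound 1 to compound 3, is unreadable in size because both ends sit at the limit of > 50 uM in this assay, at which 3 of the 3 values shown sit.

Compound 4 `C=CCCC(=O)N[C@H]1[C@@H](OCCc2ccccc2)O[C@H](COS(=O)(=O)O)[C@@H](O)[C@@H]1O` differs from compound 1 by sulfo in place of hydrogen on an oxygen on a saturated carbon; cut one bond further out this reads hydroxy to sulfooxy, hydroxymethyl to (sulfooxy)methyl. Within the data shown here, the only step that bears on it is the one from compound 1 to compound 3, whose size is not readable. Among the measured compounds shown here, no step of known size is available, so the expected step that the limit leaves unreadable from compound 1 to compound 4 is set at none beyond the scatter, with compound 4 expected to remain at the limit. Compound 4 is therefore estimated at 80 uM, with a range from 30 uM to 300 uM in this assay.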

Compound 4, concentration for 50% inhibition: > 50 uM
Compound 4 gave a limit, no number; the forecaster's own chance of this, stated with the estimate: 85%; the middle value does not contradict the limit.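

Compound 4 gives > 50 uM in this assay, a limit and not a number, so no step can be read between compound 1 and compound 4: the limit of > 50 uM in this assay, at which 4 of the 4 values shown sit.

The compounds shown leave open whether sulfo in place of hydrogen changes inhibition at all in this assay.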